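The source may report more compounds than this note shows. Statements on the series, on what has been measured and on what is new or still open speak of the compounds shown alone.

The shared core is kept in compound 1 `COc1ccc2c(=O)c(/C=C/C(=O)Nc3cc(C)ccc3C)coc2c1`, an amide whose nitrogen carries a 2,5-dimethylphenyl group. Among the measured compounds shown here, in a functional assay on Huh-7 cells (Homo sapiens) for inhibition, read by MTT assay, with a stated time of 48 h (on this read-out lower numbers stand for stronger inhibition and higher numbers for weaker inhibition), compound 1 gives 11100 nM, the only numerical value so far. Compound 2 `O=C(/C=C/c1coc2cc(O)ccc2c1=O)NCc1ccc(F)cc1` reaches only the assay limit of > 100000 nM and so gives no number. Put differently, (the limit of > 100000 nM in this assay, at which 1 of the 2 values shown sits). For the measured compounds named here, compound 1 therefore stands alone as the single measured value in this assay. Compound 3 `COc1ccc(CNC(=O)/C=C/c2coc3cc(OC)ccc3c2=O)cc1` differs from compound 1 in one place: 4-methoxybenzyl in place of 2,5-dimethylphenyl on an amide-type nitrogen. Going by the values given here, no measured pair isolates this change, so the size of the step rests on the structures alone. Compound 3 is expected to come out weaker than compound 1, with a step of a 2.7-fold higher number from compound 1 to compound 3 (0.43 log units; beyond the scatter) in this assay. Compound 3 is accordingly estimated at 30000 nM, within a range from 10000 nM to 100000 nM.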

Compound 3, half-maximal inhibitory concentration: 7570 nM
Estimate against measurement, compound 3: 4.0-fold (0.60 log units) above; the whole stated range lies above it.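

Placing 4-methoxybenzyl on the amide-type nitrogen gives a 1.5-fold lower number from compound 1 to compound 3 (0.17 log units; within the scatter) in this assay, so on this read-out the two compounds cannot be told apart. This position therefore accepts a group of 9 heavy atoms with 1 hydrogen-bond acceptor in place of one of 8 heavy atoms with 0 acceptors, with the value staying within the scatter. The values shown offer no reason for this outcome.

Among the compounds shown here, the single step changes the whole group at once, so it leaves open what the methoxy and the two methyl groups each contribute on their own. It also leaves open whether an open-chain group such as hexyl, or a benzyl group carrying a carboxylic acid, would hold the value on this amide-type nitrogen.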